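This account rests on a few compounds, and the source may have more. Where it says the series, first, only, none or still open, it means among the compounds named here.

Measured so far in a functional assay on HL-60 cells (Homo sapiens) for antiproliferative activity, read by MTT assay; on this read-out higher numbers stand for weaker inhibition and lower numbers for stronger inhibition:
compound 1 `Cn1cc(-c2cc(NS(C)(=O)=O)ccc2Oc2cccc(Br)c2)n2cncc2c1=O`, 450 nM
compound 2 `Cc1noc(C)c1-c1cccc(Oc2ccc(NS(C)(=O)=O)cc2-c2cn(C)c(=O)c3cncn23)c1`, 1230 nM
compound 3 `CCS(=O)(=O)Nc1ccc(Oc2cc(F)ccc2C)c(-c2cn(C)c(=O)c3cncn23)c1`, 440 nM

For the measured compounds named here, compound 2 gives the highest of the three numbers in this assay; nearest is compound 1, whose step a 2.7-fold higher number from compound 1 to compound 2 (0.44 log units; beyond the scatter) is the only single-change step measured, and it concerns a different position. Compound 4 `CCS(=O)(=O)Nc1ccc(Oc2cccc(-c3c(C)noc3C)c2)c(-c2cn(C)c(=O)c3cncn23)c1` differs from compound 2 by methyl in place of hydrogen on a saturated chain carbon bound to a sulfonyl sulfur. Going by the values given here, no measured pair isolates this change. Compound 3 carries the ethylsulfonyl group and gives 440 nM, but it differs from compound 2 in several places at once, so its number says nothing on its own about this step. Compound 4 is therefore expected to sit close to compound 2, with a step of a 1.0-fold lower number from compound 2 to compound 4 (0.01 log units; within the scatter) that stays within the scatter. The estimate for compound 4 in this assay is 1200 nM, range 500 nM to 2800 nM.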

Compound 4, half-maximal inhibitory concentration: 530 nM
Estimate against measurement, compound 4: 2.3-fold (0.35 log units) above, within the range that was stated.
By their numbers in this assay, from the lowest: compounds 3, 1 and 4 (each within the scatter of the next); then compound 2.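

In this assay, for the compounds shown here, the pair of compound 2 and compound 4 isolates methanesulfonamido to (ethylsulfonyl)amino for the first time, giving a 2.3-fold lower number from compound 2 to compound 4 (0.37 log units; beyond the scatter). This position therefore responds to methyl in place of hydrogen on the saturated chain carbon bound to the sulfonyl sulfur, a modest step that lies beyond the scatter. No measurement at hand accounts for this step.

On these data alone, whether a longer chain such as propyl, or a dimethylamino group on the sulfonyl sulfur, extends this step remains open. So does whether it recurs with bromo in place of 3,5-dimethyl-1,2-oxazol-4-yl.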